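Ring-nitrogen substituent changes across the shared core

The source may hold more compounds than are shown below. What is called first, only, known or untested is meant among the compounds shown, and "the series" means these compounds.

Measured so far in a functional assay on MKN-74 cells (Homo sapiens) for antiproliferative activity, with a stated time of 24 h; a higher number here means a weaker inhibitor, a lower number a stronger inhibitor:
compound 1 `NC(=O)c1c(NC(=O)c2ccccc2Cl)sc2c1CCNC2`, 28700 nM
compound 2 `N#Cc1ccccc1CN1CCc2c(sc(NC(=O)c3ccccc3Cl)c2C(N)=O)C1`, 9500 nM
compound 3 `NC(=O)c1c(NC(=O)c2ccccc2Cl)sc2c1CCN(C(=S)Nc1ccccc1-c1ccccc1)C2`, 25800 nM

Compound 2 gives the lowest number of the three. Compound 3 lies nearest, a step beyond the scatter, and compound 1 furthest; on these numbers compound 2 is the strongest inhibitor of the set in this assay.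

The next compound is compound 4 `NC(=O)c1c(NC(=O)c2ccccc2Cl)sc2c1CCN(C(=S)Nc1c(Cl)cccc1Cl)C2`. It differs from compound 2 as follows: a group of 11 heavy atoms (7 carbon, 1 nitrogen, 1 sulfur, 2 chlorine; one six-membered aromatic ring of carbon only) in place of a group of 9 heavy atoms (8 carbon, 1 nitrogen; one six-membered aromatic ring of carbon only), on an amine nitrogen in a ring

Within the data shown here, one measured step bears on this position: a 3.0-fold lower number from compound 1 to compound 2 (0.48 log units; beyond the scatter), so putting 2-cyanobenzyl on the ring nitrogen helped. Compound 3 carries a different, larger group on the same nitrogen and gives 25800 nM, close to the number of compound 1 with hydrogen there. The entering group of compound 4 resembles that of compound 3 more than 2-cyanobenzyl, so the gain seen in compound 2 is expected to be lost again, giving a number near that of compound 3.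

Compound 4 is therefore estimated at 22000 nM, within 8000 nM to 60000 nM; this expectation means a 2.3-fold higher number from compound 2 to compound 4 (0.36 log units; beyond the scatter).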

Compound 4, half-maximal inhibitory concentration: 4020 nM
Compound 4: the middle estimate sits 5.5-fold (0.74 log units) above what was measured; measured number below the stated range.
By their numbers in this assay, from the lowest: compound 4; then compound 2; then compounds 3 and 1 (each within the scatter of the next).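

In this assay, the gain at the amine nitrogen in a ring is not confined to 2-cyanobenzyl: the group in compound 4 gives a 7.1-fold lower number from compound 1 to compound 4 (0.85 log units; beyond the scatter) and goes further than 2-cyanobenzyl, with a 2.4-fold lower number from compound 2 to compound 4 (0.37 log units; beyond the scatter). The sulfur-bearing linkage does not set the number by itself, since compound 3 carries it too and remains weak, while 2,6-dichlorophenyl in place of 2-phenylphenyl gives a 6.4-fold lower number from compound 3 to compound 4 (0.81 log units; beyond the scatter), the first sign in this set that the aryl group at the far end of this substituent strongly affects the result. No measurement shown here accounts for these differences.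

Still open, as far as these compounds go, is how much of that step belongs to the two chlorine atoms, a question that a plain phenyl or a single 2-chlorophenyl on the same linkage would address. From the compounds shown here alone, it also remains open whether the sulfur of the linkage matters, which the matching urea with oxygen in its place would test, and whether the order seen in this assay holds in other cell lines.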